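The compounds below may be only part of what the source reports. "The series", "measured", "known", "first", "only" and "open" are said of these compounds alone.

Going by the values given here, compound 2 `CNC(=O)[C@H]1O[C@@H](n2cnc3c(NC4CCCC4)nc(Cl)nc32)[C@H](O)[C@@H]1O` gives the higher of the two numbers known in an assay on CHO cells for displacement of a labelled ligand from adenosine receptor A3 (Homo sapiens); a higher number here means a weaker inhibitor, a lower number a stronger inhibitor: compound 2 gives 4.27 nM, while compound 1 `CNC(=O)[C@H]1O[C@@H](n2cnc3c(NC)nc(Cl)nc32)[C@H](O)[C@@H]1O` gives 0.282 nM. Among the compounds with values here, the one measured step, a 15-fold higher number from compound 1 to compound 2 (1.18 log units; beyond the scatter), is the only guide to the change that leads to compound 3 `CNC(=O)[C@H]1O[C@@H](n2cnc3c(NCc4ccccc4C)nc(Cl)nc32)[C@H](O)[C@@H]1O`, namely (2-methylbenzyl in place of cyclopentyl on a nitrogen on an aromatic ring). That step shows the larger group weakening binding, but the 2-methylbenzyl group is of a different kind from cyclopentyl, so its effect is read only loosely from the step from compound 1 to compound 2. Compound 3 is therefore expected to land near compound 2, with a 1.4-fold lower number from compound 2 to compound 3 (0.15 log units; within the scatter), at an estimated 3 nM within 0.5 nM to 20 nM.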

Compound 3, inhibition constant: 2.19 nM
The estimate for compound 3 lay 1.4-fold (0.14 log units) above the measured number, and the stated range covers the measured number.
By their numbers in this assay, from the lowest: compound 1; then compounds 3 and 2 (each within the scatter of the next).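

In this assay, an aromatic ring and a non-aromatic ring cannot be told apart on this nitrogen: 2-methylbenzyl in place of cyclopentyl gives a 1.9-fold lower number from compound 2 to compound 3 (0.29 log units; within the scatter). Set against the methyl group, however, the 2-methylbenzyl group still gives a 7.8-fold higher number from compound 1 to compound 3 (0.89 log units; beyond the scatter), which leaves compound 1 the strongest inhibitor of the three. No evidence at hand explains these results. Still open, going by these compounds, is how an amine or a carboxylic acid on the benzyl ring, or a longer chain leading to that ring, would fare at this position.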